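Trading an Aryl Ring for Piperidine

A few compounds are considered here, and "the series" means these few. Any claim that something is new, unique, unknown or untested is made for them only; others in the source may bear on it.

In a functional assay on PANC-1 cells (Homo sapiens) for cytotoxicity, read by MTT assay, with a stated time of 72 h (on this read-out lower numbers stand for stronger inhibition and higher numbers for weaker inhibition), compound 3 `CCc1ccc(-c2ccc(NC3=CC(=O)c4ncncc4C3=O)cc2)cc1` gives 2300 nM. Compound 1 `O=C1C(Nc2ccc(-c3ccc(Cl)cc3)cc2)=CC(=O)c2ncncc21` gives 4400 nM, and a 1.9-fold lower number from compound 1 to compound 3 (0.28 log units; within the scatter) shows the two are level. Compound 2 `CN1CCN(c2ccc(NC3=CC(=O)c4ncncc4C3=O)cc2)CC1`, with 4-methylpiperazin-1-yl on that aromatic carbon, gives 340 nM. Compound 4 `O=C1C(Nc2ccc(N3CCCCC3)cc2)=CC(=O)c2ncncc21` carries piperidin-1-yl in place of 4-ethylphenyl on an aromatic carbon. Among the compounds with values here, two steps bear on this, the large 13-fold lower number from compound 1 to compound 2 (1.11 log units; beyond the scatter) and the modest 6.8-fold higher number from compound 2 to compound 3 (0.83 log units; beyond the scatter). Both favour the non-aromatic ring, though that ring differs from piperidin-1-yl, so only part of such a step is expected in this assay, towards a lower number. The estimated change is a 2.9-fold lower number from compound 3 to compound 4 (0.46 log units; beyond the scatter). For compound 4 the expected value is 800 nM, with an estimated range of 250 nM to 2500 nM.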

Compound 4, half-maximal inhibitory concentration: 1400 nM
Compound 4: middle estimate off by 1.8-fold (0.24 log units), on the low side, within the range that was stated.
By their numbers in this assay, from the lowest: compound 2; then compounds 4, 3 and 1 (each within the scatter of the next, the first and the last beyond it).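

In this assay a non-aromatic ring on this aromatic carbon is not enough on its own: the piperidin-1-yl compound stays level with the 4-ethylphenyl one (a 1.6-fold lower number from compound 3 to compound 4 (0.22 log units; within the scatter)). It does separate from the 4-chlorophenyl compound (a 3.1-fold lower number from compound 1 to compound 4 (0.50 log units; beyond the scatter)), yet 4-methylpiperazin-1-yl keeps a clear lead (a 4.1-fold higher number from compound 2 to compound 4 (0.61 log units; beyond the scatter)), so the large gain seen earlier belongs to that ring rather than to any non-aromatic ring. No evidence here gives a reason for that lead. Still open, from the compounds shown here alone, is whether the lead depends on the methyl group or on the ring itself; piperazin-1-yl without the methyl, or morpholin-4-yl, would bear on that.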